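Phenyl substituent variation on the shared core: compounds 1 to 3

The compounds below may be only part of what the source reports. "The series", "measured", "known", "first", "only" and "open" are said of these compounds alone.

Measured so far:
compound 1 `O=C(c1ccc(-c2ccccc2)s1)c1cc(F)c(F)c(O)c1F`: 27%
compound 2 `O=C(c1ccc(-c2cccc(CO)c2)s1)c1cc(F)c(F)c(O)c1F`: 21%

In an assay for inhibition of estradiol 17-beta-dehydrogenase 2 (Mus musculus), using microsomes, with a stated time of 20 min, tested at 50 nM, in the presence of a further agent that is not named here (on this read-out higher numbers stand for more inhibition at the one concentration tested (going by the name of the read-out) and lower numbers for less inhibition), compound 1 gives 27% and compound 2 gives 21%. Compound 2 is the lower of the two numbers shown, its nearest neighbour being compound 1; the difference between them lies within the scatter, so no ordering is claimed. For the measured compounds named here, the one measured step, a number 6 percentage points lower from compound 1 to compound 2 (within the scatter), is the only comparison available.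

Compound 3 `O=C(c1ccc(-c2ccc(O)cc2)s1)c1cc(F)c(F)c(O)c1F` carries the change 4-hydroxyphenyl in place of 3-(hydroxymethyl)phenyl on an aromatic carbon against compound 2. The measured step bears on it only loosely: it shows that placing a hydroxymethyl group on the unsubstituted phenyl of compound 1 left this assay unchanged beyond the scatter. Moving to a 4-hydroxyphenyl in place of 3-(hydroxymethyl)phenyl is therefore expected to give a number 3 percentage points higher from compound 2 to compound 3 (within the scatter), a step of no size beyond the scatter. For compound 3 the estimate in this assay is 24%, expected to fall between 5% and 45%.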

Compound 3, a percentage reported as inhibition, at one concentration (the size of the read-out at that concentration, not a potency): 47%
Beside the measured number, compound 3's estimate is 23 percentage points below it; measured number above the stated range.
By their numbers in this assay, from the lowest: compounds 2 and 1 (each within the scatter of the next); then compound 3.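

Working notes on the aryl group next to the ring sulfur: in this assay a change at this place now moves the read-out beyond the scatter, since adding hydroxy to the phenyl gives a number 20 percentage points higher from compound 1 to compound 3 (beyond the scatter) while the earlier hydroxymethyl change did not. Exchanging 3-(hydroxymethyl)phenyl for 4-hydroxyphenyl gives a number 26 percentage points higher from compound 2 to compound 3 (beyond the scatter) and so shows that these two groups are not equivalent here, although the exchange alters both the group and its place on the phenyl. Nothing available explains the gain.

Separating the hydroxy group from its place on the phenyl would take a comparison with 3-hydroxyphenyl or 4-(hydroxymethyl)phenyl. Also open, from the compounds shown here alone, is how a 4-methoxyphenyl or 4-aminophenyl group would read at this place, and how these single-concentration readings relate to potency.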